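The source may hold more compounds than are shown below. What is called first, only, known or untested is meant among the compounds shown, and "the series" means these compounds.

Of the compounds shown here, three built on a shared core have been measured in a functional assay on HepG2 cells (Homo sapiens) for cytotoxicity, read by MTT assay, with a stated time of 24 h; on this read-out lower numbers stand for stronger inhibition and higher numbers for weaker inhibition. Compound 1 `CN1C/C(=C\c2cccnc2)C(=O)/C(=C/c2ccccc2F)C1` gives 4810 nM, compound 2 `CN1C/C(=C\c2cccnc2)C(=O)/C(=C/c2cc([N+](=O)[O-])ccc2F)C1` gives 6630 nM, and compound 3 `CN1C/C(=C\c2cccnc2)C(=O)/C(=C/c2ccc(F)cc2Br)C1` gives 13000 nM. Compound 1 stands at the low end of this small set, though not alone: the data show a 1.4-fold higher number from compound 1 to compound 2 (0.14 log units; within the scatter), and also a 2.7-fold higher number from compound 1 to compound 3 (0.43 log units; beyond the scatter).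

Compound 4 `CN1C/C(=C\c2cccnc2)C(=O)/C(=C/c2ccccc2C(F)(F)F)C1` has not been measured yet. It differs from compound 1 by one change, trifluoromethyl in place of fluoro on an aromatic carbon, ortho to a large group.

Going by the values given here, no measured step makes this exact swap, so the guidance is indirect. Two steps alter the same aromatic ring. The nitro step stayed within the scatter, and the 2-bromo-4-fluorophenyl step, the only one beyond it, was modest and led to a higher number. A small move toward a higher number is therefore expected in this assay, a 1.7-fold higher number from compound 1 to compound 4 (0.22 log units; within the scatter). For compound 4 the estimate is 8000 nM, with an expected range from 3500 nM to 18000 nM.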

Compound 4, half-maximal inhibitory concentration: 2550 nM
For compound 4 the middle estimate is 3.1-fold (0.50 log units) above the measured one; measured number below the stated range.
By their numbers in this assay, from the lowest: compounds 4, 1, 2 and 3 (each within the scatter of the next, the first and the last beyond it).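

In this assay, trifluoromethyl in place of fluoro gives a 1.9-fold lower number from compound 1 to compound 4 (0.28 log units; within the scatter), so this aromatic carbon carries a group of 4 heavy atoms instead of 1 with no difference that stands clear of the scatter. Going by these compounds alone, the earlier steps could not show this, since the nitro step left the fluoro in place and the 2-bromo-4-fluorophenyl step altered the ring in more than one place, so this is the first step that replaces the fluoro alone. Nothing available here gives a measured reason for this result.

The compounds shown leave open whether a methoxy group, an amine or a carboxylic acid on this same carbon would also stay within the scatter. They also leave open whether this holds in any other assay.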